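The compounds below may be only part of what the source reports. "The series", "measured", "known", "first", "only" and "open" are said of these compounds alone.

Measured compounds:
- compound 1, `Cc1nc(C(C)(C)C)nc2nc(N)c(C#N)c(N)c12`, for which a physicochemical assay for solubility, in phosphate buffer, with a stated time of 18 h (a lower number here means a less soluble compound, a higher number a more soluble compound), gives compound 1 a value of 37000 nM
- compound 2, `CC(C)(C)c1nc(-c2cccs2)c2c(N)c(C#N)c(N)nc2n1`, for which this assay gives compound 2 a value of 56000 nM

Compound 2 has the highest of the two numbers recorded in this assay, but its nearest neighbour is compound 1, and the step between them, a 1.5-fold higher number from compound 1 to compound 2 (0.18 log units; within the scatter), is within the scatter, so the two cannot be told apart.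

The next compound is compound 3, `CC(C)(C)c1nc(-c2nc(CO)cs2)c2c(N)c(C#N)c(N)nc2n1`, which has not yet been measured. Compared with compound 2, the change is 4-(hydroxymethyl)-1,3-thiazol-2-yl in place of thiophen-2-yl on an aromatic carbon.

Among the measured compounds shown here, only one measured step exists, and it concerns a different change on the same position; the replacement of methyl by thiophen-2-yl, a 1.5-fold higher number from compound 1 to compound 2 (0.18 log units; within the scatter), was within the scatter. For the measured compounds named here, no measured step covers the change from compound 2 to compound 3, so any expectation rests on weak ground. A modest rise in the number is expected, with the step of a 1.6-fold higher number from compound 2 to compound 3 (0.21 log units; within the scatter) perhaps just beyond the scatter. Compound 3 is estimated to give 90000 nM in this assay, within a range from 40000 nM to 200000 nM.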

Compound 3, solubility: < 1000 nM
Compound 3 ended at the assay's limit; the forecaster's own chance of this, stated with the estimate: 5%; middle value at least 90-fold (1.95 log units) from the limit.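

The earlier pair made the group on this aromatic carbon look freely exchangeable in this assay, as methyl and thiophen-2-yl could not be told apart, with a 1.5-fold higher number from compound 1 to compound 2 (0.18 log units; within the scatter). Compound 3 changes that picture: placing 4-(hydroxymethyl)-1,3-thiazol-2-yl here in place of thiophen-2-yl gives an at least 56-fold lower number from compound 2 to compound 3 (1.74 log units; beyond the scatter), and placing it here in place of methyl gives an at least 37-fold lower number from compound 1 to compound 3 (1.56 log units; beyond the scatter), so the large step appears against both of the earlier groups and this position is clearly not indifferent to what it carries. The result for compound 3 is a limit of the assay and not a number: the limit of < 1000 nM in this assay, at which 1 of the 3 values shown sits.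

The change alters two things at once, the ring itself and the hydroxymethyl group it carries, and the three compounds shown cannot separate these two parts. An unsubstituted 1,3-thiazol-2-yl, a thiophen-2-yl bearing hydroxymethyl, or a thiazole carrying an amine or a carboxylic acid in place of hydroxymethyl would each be needed to tell whether the ring nitrogen, the hydroxymethyl group or only their combination goes with the step.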